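Moving the chlorine from 2-chlorophenyl to 3-chlorophenyl

The compounds below may be only part of what the source reports. "The series", "measured", "known", "first", "only" and "open" are said of these compounds alone.

Measured in a functional assay on HepG2 cells (Homo sapiens) for antiproliferative activity, read by sulforhodamine B assay, with a stated time of 72 h; on this read-out lower numbers stand for stronger inhibition and higher numbers for weaker inhibition:
Compound 1 `COc1ccc(NC(=O)Cn2nc(-c3ccccc3)c3ccccc3c2=O)cc1`: > 100000000 nM
Compound 2 `O=C(Cn1nc(-c2ccccc2)c2ccccc2c1=O)Nc1ccccc1Cl`: 33000 nM

The entry for compound 1, > 100000000 nM, is a limit of the assay. For the measured compounds named here, compound 2 holds the only actual number, 33000 nM. Compound 3 `O=C(Cn1nc(-c2ccccc2)c2ccccc2c1=O)Nc1cccc(Cl)c1` carries 3-chlorophenyl in place of 2-chlorophenyl on an amide-type nitrogen. Going by the values given here, the one measured step, an at least 3000-fold lower number from compound 1 to compound 2 (3.48 log units; beyond the scatter), changed the group on that same nitrogen, but it starts from a limit and replaced a different group, so it guides this move only weakly. The expected size is a 1.2-fold higher number from compound 2 to compound 3 (0.08 log units; within the scatter), with no step beyond the scatter expected in this assay. The estimate for compound 3 is 40000 nM, within a range of 10000 nM to 200000 nM.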

Compound 3, half-maximal inhibitory concentration: 3290 nM
Compound 3: the middle estimate sits 12-fold (1.08 log units) above what was measured, and the stated range ends above it.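

In this assay, for the compounds shown here, relocating the chlorine while keeping the same atoms gave a 10-fold lower number from compound 2 to compound 3 (1.00 log units; beyond the scatter), so the placement of a single chlorine on the phenyl group matters here, which the earlier compounds, differing in the whole group, could not show. The wider step, an at least 30000-fold lower number from compound 1 to compound 3 (4.48 log units; beyond the scatter), gives only a bound. Its starting entry for compound 1 is a limit of the assay, not a number: the limit of > 100000000 nM in this assay, at which 1 of the 3 values shown sits.

Going by these compounds, whether 4-chlorophenyl would give a lower or higher number than 3-chlorophenyl remains open. So does whether 3-bromophenyl or 3-methoxyphenyl would match 3-chlorophenyl.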